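The source may report more compounds than this note shows. Statements on the series, on what has been measured and on what is new or still open speak of the compounds shown alone.

Measured so far:
- compound 1, `CC#CC(CC(=O)O)c1ccc(OCc2ccc3nc(-c4ccc(OC)cc4)cn3c2)cc1`: 47 nM
- compound 2, `CC#CC(CC(=O)O)c1ccc(OCc2ccc3nc(-c4ccc(C)cc4C)cn3c2)cc1`: 316 nM

Both were tested in an assay on isolated protein for agonist activity at Free fatty acid receptor 1 (Homo sapiens); on this read-out lower numbers stand for an effect already at smaller amounts and higher numbers for an effect only at larger amounts of compound. Compound 2 stands at the higher of the two numbers; its nearest neighbour is compound 1, and the step of a 6.7-fold higher number from compound 1 to compound 2 (0.83 log units; beyond the scatter) separates them. That single step is the only one on record, and it arises from exchanging the aryl group attached to the shared core.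

Compound 3, `CC#CC(CC(=O)O)c1ccc(OCc2ccc3nc(-c4cccc(C)c4)cn3c2)cc1`, has not yet been tested. It differs from compound 2 by 3-methylphenyl in place of 2,4-dimethylphenyl on an aromatic carbon. Going by the values given here, this again changes only the aryl group on the shared core, so the step from compound 1 to compound 2 is the one measured step that bears on it. That step was modest but beyond the scatter, and it shows that the choice of aryl group matters in this assay. Nothing measured tells how a 3-methylphenyl compares with either of the two aryl groups tried, so the direction is uncertain; as an expectation, compound 3 is placed between the two measured values, with a step of a 2.1-fold lower number from compound 2 to compound 3 (0.32 log units; beyond the scatter) toward a lower number. The estimate for compound 3 is therefore 150 nM, expected to fall within 50 nM to 450 nM.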

Compound 3, half-maximal effective concentration: 1050 nM
Compound 3: middle estimate off by 7.0-fold (0.85 log units), on the low side; measured number outside the range, above it.
By their numbers in this assay, from the lowest: compound 1; then compound 2; then compound 3.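

The three compounds show that in this assay the aryl group on this aromatic carbon, two ring bonds from the ring nitrogen, has more influence than the first pair alone could reveal, with a 22-fold higher number from compound 1 to compound 3 (1.35 log units; beyond the scatter) as a large step from a single exchange on the shared core. Even a small edit counts here: 3-methylphenyl has 7 heavy atoms against 8 in 2,4-dimethylphenyl, neither group has a hydrogen-bond donor or acceptor, and yet the exchange gives a 3.3-fold higher number from compound 2 to compound 3 (0.52 log units; beyond the scatter) and this step lies beyond the usual scatter. Nothing available explains why these aryl groups give different numbers, so the ranking stays a plain observation for these three compounds.

From the compounds shown here alone, the change from compound 2 to compound 3 alters both the number of methyl groups and their placement at once, so the contribution of each remains open. Also open, going by these compounds, is how this aryl ring would respond to other groups, such as an amine, a nitrile or a chlorine atom, and whether any of them would match or improve on the 4-methoxyphenyl of compound 1.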